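A few compounds are considered here, and "the series" means these few. Any claim that something is new, unique, unknown or untested is made for them only; others in the source may bear on it.

Two compounds share one core and differ only in the aryl group attached to it. Compound 1 `COc1cc(-c2cc(-c3cc(C(C)C)c(O)cc3C)[nH]c(=O)c2C#N)cc(OC)c1OC` carries a trimethoxyphenyl group there and gives 71% in a functional assay for inhibition, tested at 60 ug/mL; a higher number here means a stronger effect of the compound at the concentration tested, a lower number a weaker effect. Compound 2 `COc1ccc(-c2cc(-c3cc(C(C)C)c(O)cc3C)[nH]c(=O)c2C#N)cc1` carries a 4-methoxyphenyl group in the same place and gives 43% in this assay. Within the data shown here, of the two numbers measured so far, compound 2 stands lowest, and the nearest number, that of compound 1, lies well beyond the usual scatter above it.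

Compound 3 `Cc1cc(O)c(C(C)C)cc1-c1cc(-c2ccccc2[N+](=O)[O-])c(C#N)c(=O)[nH]1` has not yet been measured. The change from compound 2 to compound 3 is 2-nitrophenyl in place of 4-methoxyphenyl on an aromatic carbon. Among the measured compounds shown here, no measured pair shows what this particular exchange does, so the direction of the step cannot be read from the data. For the measured compounds named here, the expectation for the step from compound 2 to compound 3 is a number 3 percentage points lower from compound 2 to compound 3 (within the scatter), a change no larger than the scatter, since the one comparison available, between compound 1 and compound 2, only shows that the aryl group can shift the read-out. Compound 3 is therefore estimated at 40%, in a range from 20% to 65%.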

Compound 3, a percentage reported as inhibition, at one concentration (the size of the read-out at that concentration, not a potency): 31%
Beside the measured number, compound 3's estimate is 9 percentage points above it; the range from low to high includes it.
By their numbers in this assay, from the lowest: compound 3; then compound 2; then compound 1.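

In this assay, the change to 2-nitrophenyl on this aromatic carbon, ortho to a cyano group and opposite the ring nitrogen, gives a number 12 percentage points lower from compound 2 to compound 3 (beyond the scatter) and the step is a modest one. The earlier pair showed only that this position can shift the read-out between two methoxy-bearing phenyl groups; this step shows that a phenyl group with no methoxy at all can also move it, here downward, so the position responds to more than the number of methoxy groups. Nothing measured alongside these numbers speaks to why the read-out moves.

The exchange alters both the kind of group on the phenyl ring and where that group sits, so this single step cannot separate the two, and 4-nitrophenyl or 2-methoxyphenyl would be needed to pull them apart. Also open, as far as these compounds go, is how an unsubstituted phenyl ring, or a phenyl ring carrying an amine or a carboxylic acid, would compare at this position, and each figure here describes one concentration rather than a potency.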